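This account rests on a few compounds, and the source may have more. Where it says the series, first, only, none or still open, it means among the compounds named here.

Compound 1 `Cc1ccc(S(=O)(=O)n2cc(-c3cc(C(F)(F)F)ccn3)c3cc(Br)ccc32)cc1` gives 32.8% in a functional assay on A549 cells (Homo sapiens) for inhibition, tested at 1 uM; a higher number here means a stronger effect of the compound at the concentration tested, a lower number a weaker effect. Compound 2 `Cc1ccc(S(=O)(=O)n2cc(-c3cc(C(F)(F)F)cc(-c4cn(S(=O)(=O)c5ccc(C)cc5)c5ccccc45)n3)c3ccccc32)cc1` gives 36.7% in the same test, and compound 3 `Cc1ccc(S(=O)(=O)n2cc(-c3cc(C(F)(F)F)c(C#N)c(-c4cn(S(=O)(=O)c5ccc(C)cc5)c5cc(Br)ccc45)n3)c3ccc(Br)cc32)cc1` gives 18.8%. Compound 1 thus holds the second highest of the three numbers: its gap to compound 2 lies within the scatter, while compound 3 sits beyond the scatter with the lower number. Compound 4 `Cc1ccc(S(=O)(=O)n2cc(-c3cc(C(F)(F)F)ccn3)c3ccccc32)cc1` has not yet been measured. It differs from compound 1 by a single change (hydrogen in place of bromo on an aromatic carbon). Among the measured compounds shown here, no measured pair shows this change on its own. Compound 2 also lacks the bromo and gives 36.7% in this assay. On that basis the expected step of a number 3.8 percentage points lower from compound 1 to compound 4 (within the scatter) is small, in no direction beyond the scatter. Compound 4 is therefore estimated at 29%, with a range from 13% to 43%.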

Compound 4, a percentage reported as inhibition, at one concentration (the size of the read-out at that concentration, not a potency): 29.2%
Estimate against measurement, compound 4: 0.2 percentage points below; the range from low to high includes it.
By their numbers in this assay, from the lowest: compound 3; then compounds 4, 1 and 2 (each within the scatter of the next).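

Among the compounds shown here, the first direct reading of this change at this position is a number 3.6 percentage points lower from compound 1 to compound 4 (within the scatter) in this assay, with hydrogen in place of bromo on an aromatic carbon. In this pair, the bromo can be exchanged for hydrogen without a step beyond the scatter, so the read-out at this concentration does not depend on the bromo. No measurement shown bears on the reason for this step.

On these data alone, whether an amine, a methoxy group or a carboxylic acid on this same carbon would give a different read-out stays open. So does whether removing the bromo from the core of compound 3 would give a similar step.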